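Series notes: amino for chloro on the fused ring

A few compounds are considered here, and "the series" means these few. Any claim that something is new, unique, unknown or untested is made for them only; others in the source may bear on it.

Compound 1 `Nc1nn(C(=O)Nc2ccc(Cc3ccccc3)cc2)c2ccccc12` and compound 2 `Nc1nn(C(=O)Nc2ccc(Cc3ccccc3)cc2)c2ccc(Cl)cc12` share one core. In a functional assay on RXF 393 cells (Homo sapiens) for antiproliferative activity, read by sulforhodamine B assay, with a stated time of 48 h (on this read-out higher numbers stand for lower toxicity in this test and lower numbers for higher toxicity in this test), compound 1 gives only a limit of the test, > 100000 nM. In this assay, among the compounds with values here, compound 2 gives 73400 nM, the only number so far. The remaining entry, that of compound 1, is a limit (the limit of > 100000 nM in this assay, at which 1 of the 2 values shown sits). Within the data shown here, the step of an at least 1.3-fold lower number from compound 1 to compound 2 (0.13 log units; that floor lies within the scatter) is the sole measured step, and its floor lies within the scatter, so it gives no firm direction.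

Compound 3 `Nc1ccc2c(c1)c(N)nn2C(=O)Nc1ccc(Cc2ccccc2)cc1` differs from compound 2 by amino in place of chloro on an aromatic carbon. Among the measured compounds shown here, no measured step covers an amino group at this place, and the one measured step at this carbon stays within the scatter. A step beyond the scatter is therefore not expected in either direction, though a limit remains possible. Compound 3 is expected to give about 90000 nM in this assay, between 40000 nM and 200000 nM, which means an expected step of a 1.2-fold higher number from compound 2 to compound 3 (0.09 log units; within the scatter).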

Compound 3, concentration lethal to 50% of the cells: 90100 nM
Beside the measured number, compound 3's estimate is 1.0-fold (0.00 log units) below it, and the stated range covers the measured number.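

In this assay, the change from chloro to amino on this aromatic carbon gives a 1.2-fold higher number from compound 2 to compound 3 (0.09 log units; within the scatter), so two quite different groups at this place, one of them carrying a hydrogen-bond donor and acceptor that chloro lacks, give values within the scatter of each other. Against hydrogen at the same carbon, the reading is an at least 1.1-fold lower number from compound 1 to compound 3 (0.04 log units; that floor lies within the scatter), and this floor gives no direction, just as the floor of the step to chloro gave none. The value of compound 1 is a limit, and because of it both comparisons with hydrogen stay one-sided: the limit of > 100000 nM in this assay, at which 1 of the 3 values shown sits.

Still open, going by these compounds, is whether a carboxylic acid, a methoxy group or a longer chain on this carbon would give a step beyond the scatter. Also open, on these data alone, is whether a change elsewhere on the shared core would do so.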